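Bromophenyl to trifluoromethylphenyl on a shared core

The source may hold more compounds than are shown below. What is called first, only, known or untested is meant among the compounds shown, and "the series" means these compounds.

Compound 1 `Brc1cn2ccnc2c(-c2ccc3ncn(C4CCCCC4)c3c2)n1` carries a bromo group on an aromatic carbon of its core, and in a functional assay on U-251 cells (Homo sapiens) for inhibition, read by sulforhodamine B assay, with a stated time of 48 h, tested at 10 uM (a lower number here means less inhibition, a higher number more inhibition at the concentration tested (going by the name of the read-out)), compound 1 gives 1.5%. Compound 2 `Brc1ccc(-c2cn3ccnc3c(-c3ccc4ncn(C5CCCCC5)c4c3)n2)cc1` has a 4-bromophenyl in that place instead, and in this assay compound 2 gives 23.7%. Among the compounds with values here, the only measured step is a number 22.2 percentage points higher from compound 1 to compound 2 (beyond the scatter). Within the data shown here, compound 2 therefore stands highest of the two numbers so far, with compound 1 as its nearest neighbour.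

Compound 3 `FC(F)(F)c1cccc(-c2cn3ccnc3c(-c3ccc4ncn(C5CCCCC5)c4c3)n2)c1` is the next member. Its difference from compound 2 is 3-(trifluoromethyl)phenyl in place of 4-bromophenyl on an aromatic carbon. Among the measured compounds shown here, no measured step shows an exchange of one aryl group for another; the single known step only replaced a bromo atom with an aryl ring. Because that step, a number 22.2 percentage points higher from compound 1 to compound 2 (beyond the scatter), concerned a different kind of change, it gives no direction for the present one. The expectation is that compound 3 stays in the neighbourhood of compound 2, with a step of a number 1.7 percentage points lower from compound 2 to compound 3 (within the scatter) that is expected to lie within the scatter. Compound 3 is thus estimated to give 22% in this assay, within a range from 5% to 45%.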

Compound 3, a percentage reported as inhibition, at one concentration (the size of the read-out at that concentration, not a potency): 5.93%
Estimate against measurement, compound 3: 16.1 percentage points above; measured number inside the range.
By their numbers in this assay, from the lowest: compounds 1 and 3 (each within the scatter of the next); then compound 2.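

The exchange of one aryl group for another at this position is not neutral in this assay, with a number 17.8 percentage points lower from compound 2 to compound 3 (beyond the scatter), so the gain seen when an aryl ring replaced the bromo group does not extend to every aryl ring. Measured against the bromo compound, the 3-(trifluoromethyl)phenyl group gives a number 4.4 percentage points higher from compound 1 to compound 3 (within the scatter), which means that of the two aryl groups shown, only the 4-bromophenyl stands clearly apart from compound 1. Nothing accompanying these numbers accounts for the difference between the two aryl groups.

Compound 2 and compound 3 differ both in the substituent on the phenyl ring and in where it sits on that ring, so these compounds cannot separate the effect of the group from that of its placement. Also open, going by these compounds, is how a plain phenyl ring, or a phenyl ring carrying an amine or a carboxylic acid, would read at this position on the shared core.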